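A New Group on the Sulfonyl Sulfur of Compound 3

The source may hold more compounds than are shown below. What is called first, only, known or untested is meant among the compounds shown, and "the series" means these compounds.

- Compound 1 `CC1CCN(C2CCN(S(=O)(=O)c3cccnc3F)CC2)CC1` gives the limit > 10000 nM here
- Compound 2 `CC1CCN(C2CCN(S(=O)(=O)c3nccn3C)CC2)CC1` gives the limit > 10000 nM here
- Compound 3 `CC1CCN(C2CCN(S(=O)(=O)c3cccc(Cl)c3)CC2)CC1` gives the limit > 5000 nM here

These readings come from an ADME assay on HCT-116 cells (Homo sapiens) for cytotoxicity, read by CellTiter-Glo, with a stated time of 72 h (a higher number here means a weaker inhibitor, a lower number a stronger inhibitor), and each is a limit of the assay, not a number. Compound 3 therefore has no exact position on the scale, only its limit of > 5000 nM and no number.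

Compound 4 `Cc1nc(Cl)sc1S(=O)(=O)N1CCC(N2CCC(C)CC2)CC1` keeps the rest of compound 3 and changes one group: 2-chloro-4-methyl-1,3-thiazol-5-yl in place of 3-chlorophenyl on a sulfonyl sulfur. The measured changes at this same place on the sulfonyl sulfur are the guide: a step that the two limits leave unreadable from compound 1 to compound 3, a step that the two limits leave unreadable from compound 2 to compound 3 and a step that the two limits leave unreadable from compound 1 to compound 2. None of them has a size that can carry over, so the data give no direction for the new group. A further limit is the likeliest report from this assay.

The expected change is a step that the limit leaves unreadable from compound 3 to compound 4, which would be no step beyond the scatter. For compound 4 the estimated value is 8000 nM, with an expected range from 3000 nM to 20000 nM.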

Compound 4, half-maximal inhibitory concentration: > 10000 nM
Compound 4: no number, only a limit; the forecaster's own chance of this, stated with the estimate: 85%; middle value at least 1.2-fold (0.09 log units) from the limit.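

The steps to compound 4 from compound 1, compound 2 and compound 3 cannot be read: all four compounds give limits, not numbers. The compounds shown leave open whether any group on the sulfonyl sulfur would give an exact number in this assay.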